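Aryl swap at the carbonyl carbon: compound 1 to compound 4

The compounds below may be only part of what the source reports. "The series", "measured", "known", "first", "only" and "open" are said of these compounds alone.

For the measured compounds named here, compound 1 `COc1cc(-c2cc(/C=C/C(=O)c3ccc(Cl)c(Cl)c3)[nH]n2)cc(OC)c1OC` stands highest of the three numbers so far: in a functional assay on A549 cells (Homo sapiens) for cytotoxicity, read by sulforhodamine B assay, with a stated time of 48 h, tested at 1 uM (a higher number here means a weaker effect of the compound at the concentration tested, a lower number a stronger effect), compound 1 gives 93%. Compound 2 `COc1ccc(-c2cc(/C=C/C(=O)c3ccc(N)cc3)[nH]n2)cc1OC` gives 89% in this assay, a gap to compound 1 within the scatter. Compound 3 `COc1ccc(-c2cc(/C=C/C(=O)c3cc(OC)c(OC)c(OC)c3)[nH]n2)cc1OC` gives 82% in this assay, a gap to compound 1 beyond the scatter. Compound 4 `COc1ccc(C(=O)/C=C/c2cc(-c3cc(OC)c(OC)c(OC)c3)n[nH]2)cc1OC` is not yet measured. Its change from compound 1: 3,4-dimethoxyphenyl in place of 3,4-dichlorophenyl on a carbonyl carbon. Going by the values given here, no measured pair isolates this change. Compound 3 is the nearest comparison with its 82%, so for compound 4 a modest step towards a stronger effect is expected, a number 8 percentage points lower from compound 1 to compound 4 (within the scatter), possibly still within the scatter. The expected value for compound 4 in this assay is 85%, with a range from 70% to 97%.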

Compound 4, a percentage reported as activity, at one concentration (the size of the read-out at that concentration, not a potency): 84%
The estimate for compound 4 lay 1 percentage points above the measured number; the range from low to high includes it.
By their numbers in this assay, from the lowest: compounds 3, 4, 2 and 1 (each within the scatter of the next, the first and the last beyond it).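

In this assay, for the compounds shown here, the swap to 3,4-dimethoxyphenyl in place of 3,4-dichlorophenyl on a carbonyl carbon gives a number 9 percentage points lower from compound 1 to compound 4 (within the scatter) and is the only step that isolates this position. On the core of compound 1, this change of aryl group therefore does not move the read-out beyond the scatter at the single concentration tested. No measured data bear on why this step has its size.

From the compounds shown here alone, whether a carboxylic acid or a morpholine in place of 3,4-dichlorophenyl on a carbonyl carbon would give a step beyond the scatter remains open. Also open, going by these compounds, is whether another concentration would separate compound 1 from compound 4.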